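The compounds below may be only part of what the source reports. "The series", "measured", "known", "first", "only" and "open" are said of these compounds alone.

Compound 1 `O=C(c1cc(-c2cn[nH]c2)on1)N1CCC(Cc2ccc(Cl)cc2)CC1` gives 0.6%
Compound 2 `O=C(Nc1ccc2[nH]c(=O)oc2c1)C(=O)N1CCN(c2ccc(Cl)cc2)CC1` gives 17.8%
Compound 3 `O=C(Nc1ccc2[nH]c(=O)oc2c1)C(=O)N1CCN(c2ccc(F)cc2)CC1` gives 39.3%

In an ADME assay on the whole organism (Rattus norvegicus, strain Sprague-Dawley) for pharmacokinetics, using cassette dosing, at a dose of 1 mg/kg by the oral route (a higher number here means that a larger share of the oral dose reaches the circulation, a lower number that a smaller share of the oral dose reaches the circulation), compound 3 stands highest of the three, clearly above both others. Compound 4 `O=C(Nc1ccc2[nH]c(=O)oc2c1)C(=O)N1CCN(c2ccc(C(F)(F)F)cc2)CC1` differs from compound 3 in one place, with trifluoromethyl in place of fluoro on an aromatic carbon and nothing else changed. Within the data shown here, the one measured guide is a number 21.5 percentage points higher from compound 2 to compound 3 (beyond the scatter) with fluoro in place of chloro on that carbon, which suggests that moving away from fluoro could lower the number again. A single step is thin evidence, and trifluoromethyl is not chloro. The expected change is a number 17.3 percentage points lower from compound 3 to compound 4 (beyond the scatter) in this estimate. The estimated value for compound 4 is 22% within an expected range of 7% to 40% in this assay's terms.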

Compound 4, oral bioavailability: 24.8%
For compound 4 the middle estimate is 2.8 percentage points below the measured one; the measured number falls inside the stated range.
By their numbers in this assay, from the lowest: compound 1; then compounds 2 and 4 (each within the scatter of the next); then compound 3.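

In this assay, among these compounds, trifluoromethyl in place of fluoro gives a number 14.5 percentage points lower from compound 3 to compound 4 (beyond the scatter), so chloro is no longer the only group at this aromatic carbon that falls short of fluoro. Trifluoromethyl and chloro cannot be told apart here, with a number 7 percentage points higher from compound 2 to compound 4 (within the scatter) as the step between them, so among these three groups only fluoro stands apart. Nothing available here explains why these groups differ. Still open, as far as these compounds go, is whether a methoxy group, an amine or a nitrile on this carbon would match fluoro. Also open, from the compounds shown here alone, is whether the standing of fluoro would hold on a different core.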